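Morpholine Urea in Place of a Cyclopentylmethyl Amide

The source may report more compounds than this note shows. Statements on the series, on what has been measured and on what is new or still open speak of the compounds shown alone.

Two compounds of this series carry a measurement in a physicochemical assay for solubility, at pH 7.4; on this read-out higher numbers stand for higher solubility and lower numbers for lower solubility. Compound 1 `CC(C)(C)c1cc(NC(=O)N2CCCN(C(=O)C3CCOCC3)CC2)no1` gives > 96 ug/mL, which is a limit of the assay rather than a number. For the measured compounds named here, compound 2 `CC(C)(C)c1ccc2oc(N3CCCN(C(=O)CC4CCCC4)CC3)nc2c1` gives 26 ug/mL in this assay; this is the only number reported. Compound 3 `CC(C)(C)c1ccc2oc(N3CCCN(C(=O)N4CCOCC4)CC3)nc2c1` has not yet been measured. It differs from compound 2 in a single place: morpholin-4-yl in place of cyclopentylmethyl on a carbonyl carbon whose other neighbours are an amide-type nitrogen in a ring. Going by the values given here, no pair of measured compounds differing in one place is available, so the size of this step cannot be read from a measured step. In this assay the expected step is a 3.1-fold higher number from compound 2 to compound 3 (0.49 log units; beyond the scatter), an increase beyond the usual scatter. Compound 3 is estimated at 80 ug/mL in this assay, within a range from 30 ug/mL to 200 ug/mL.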

Compound 3, solubility: > 113 ug/mL
Compound 3 ended at the assay's limit; the forecaster's own chance of this, stated with the estimate: 40%; middle value at least 1.4-fold (0.14 log units) away from the limit.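

Morpholin-4-yl in place of cyclopentylmethyl on a carbonyl carbon gives an at least 4.3-fold higher number from compound 2 to compound 3 (0.63 log units; beyond the scatter) in this assay and this is the first step that can be read at this position. Both groups hold 6 heavy atoms and neither carries a net charge, so the step comes with no change in size by that count, while the entering group has one hydrogen-bond acceptor and the leaving group has none. Compound 3 gives > 113 ug/mL and that is a limit and not a number, so the step is only a lower bound on the real difference.

As far as these compounds go, how far compound 3 lies past that limit remains open. Also open, from the compounds shown here alone, is whether a piperidin-1-yl or a dimethylamino group on the same carbonyl carbon would give a step of similar size, which would show whether the ring oxygen of morpholin-4-yl is needed.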